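The source may hold more compounds than are shown below. What is called first, only, known or untested is meant among the compounds shown, and "the series" means these compounds.

Measured so far:
- Compound 1, `Cc1n[nH]c(C(=O)O)c1Cc1ccc(C(F)(F)F)cc1`: in an assay on isolated protein for inhibition of 2-Hydroxyacid oxidase 2 (Homo sapiens), tested at 10 uM (on this read-out lower numbers stand for a weaker effect and higher numbers for a stronger effect at the one concentration tested), compound 1 gives 12%.
- Compound 2, `Cc1n[nH]c(C(=O)O)c1Cc1ccc(C(N)=O)cc1`: in this assay compound 2 gives 8%.
- Compound 3, `Cc1n[nH]c(C(=O)O)c1Cc1ccc(-c2ccc(F)cc2)cc1`: in this assay compound 3 gives 25%.

Compound 3 stands highest of the three numbers. The step of a number 13 percentage points higher from compound 1 to compound 3 (beyond the scatter) and the step of a number 17 percentage points higher from compound 2 to compound 3 (beyond the scatter) are both beyond the scatter, while compound 1 and compound 2 show a step of a number 4 percentage points lower from compound 1 to compound 2 (within the scatter) that is within it.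

The next compound is compound 4, `Cc1n[nH]c(C(=O)O)c1Cc1ccc(-c2ccc(OC(F)(F)F)cc2)cc1`, not yet measured. Its change from compound 3 is trifluoromethoxy in place of fluoro on an aromatic carbon, on an aromatic carbon of a six-membered aromatic ring of carbon only, para to a large group. Among the compounds with values here, none of the measured steps touches this position: the two steps into compound 3 exchanged the whole terminal group for 4-fluorophenyl and were modest in size, so they bear on compound 4 only by showing that the added ring is tolerated. Within the data shown here, no precedent for the change of its substituent exists here. The expectation is therefore a step of a number 5 percentage points higher from compound 3 to compound 4 (within the scatter) that stays within the scatter or is at most a small rise. Compound 4 is estimated at 30%, with a range from 15% to 45%.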

Compound 4, a percentage reported as inhibition, at one concentration (the size of the read-out at that concentration, not a potency): 29%
For compound 4 the middle estimate is 1 percentage points above the measured one; measured number inside the range.
By their numbers in this assay, from the lowest: compounds 2 and 1 (each within the scatter of the next); then compounds 3 and 4 (each within the scatter of the next).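

In this assay, trifluoromethoxy in place of fluoro, on an aromatic carbon of a six-membered aromatic ring of carbon only, para to a large group, gives a number 4 percentage points higher from compound 3 to compound 4 (within the scatter). Within the data shown here, this is the first reading at this position, and it shows that the position accepts the larger trifluoromethoxy group, with its added hydrogen-bond acceptor, without a separation from the fluoro compound. No measurement available here bears on why the two substituents read alike.

Still open, going by these compounds, is whether any group at this position can move the read-out beyond the scatter; an amine, a carboxylic acid or a longer alkyl chain there would test this. Also open, on these data alone, is how much the carboxylic acid of the shared core contributes, which an ester or primary amide in its place would address.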